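This account rests on a few compounds, and the source may have more. Where it says the series, first, only, none or still open, it means among the compounds named here.

Measured compounds in an assay on isolated protein for binding affinity to vascular endothelial growth factor A, long form (Homo sapiens), read by surface plasmon resonance; on this read-out higher numbers stand for weaker binding and lower numbers for tighter binding:

compound 1 `CO[C@H]1O[C@H](CNC(=O)CN(CCOS(=O)(=O)O)C(C)=O)[C@@H](OS(=O)(=O)O)[C@H](OS(=O)(=O)O)[C@@H]1OS(=O)(=O)O`: 280000 nM
compound 2 `CO[C@H]1O[C@H](CNC(=O)CN(C(C)=O)C2CCCCCC2)[C@@H](OS(=O)(=O)O)[C@H](OS(=O)(=O)O)[C@@H]1OS(=O)(=O)O`: 3000000 nM
compound 3 `CCN(CC(=O)NC[C@H]1O[C@H](OC)[C@@H](OS(=O)(=O)O)[C@@H](OS(=O)(=O)O)[C@@H]1OS(=O)(=O)O)C(=O)CCc1ccccc1`: 596000 nM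

Among these three, compound 3 gives the second highest number in this assay. Compound 1 lies nearest to it, with a lower number that is still beyond the scatter, and compound 2 lies furthest, with a higher number that is also beyond the scatter. Compound 4 `CCN(CC(=O)NC[C@H]1O[C@H](OC)[C@@H](OS(=O)(=O)O)[C@@H](OS(=O)(=O)O)[C@@H]1OS(=O)(=O)O)C(=O)CCCCC(=O)O` is not yet measured; it differs from compound 3 by 2-carboxyethyl in place of phenyl on a saturated chain carbon, two bonds along the chain from a carbonyl carbon.

For the measured compounds named here, only one measured step touches the same region of the molecule, the one from compound 1 to compound 2, where an open chain was replaced by a ring: an 11-fold higher number from compound 1 to compound 2 (1.03 log units; beyond the scatter). The change from compound 3 to compound 4 runs in the opposite sense, a ring leaving and an open chain entering, though the groups themselves are not the same as in that step. On that single precedent, a move toward a lower number is expected, but smaller than the one seen, since the match is loose. Compound 4 is therefore expected to give about 300000 nM, within a range from 120000 nM to 800000 nM. The estimated step is a 2.0-fold lower number from compound 3 to compound 4 (0.30 log units; within the scatter).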

Compound 4, dissociation constant: 104000 nM
Estimate against measurement, compound 4: 2.9-fold (0.46 log units) above; measured number outside the range, below it.
By their numbers in this assay, from the lowest: compound 4; then compound 1; then compound 3; then compound 2.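

In this assay, for the compounds shown here, replacing phenyl with 2-carboxyethyl on a saturated chain carbon, two bonds along the chain from a carbonyl carbon, gives a 5.7-fold lower number from compound 3 to compound 4 (0.76 log units; beyond the scatter), so this position, which the earlier compounds had not probed on its own, does respond to the group placed there, and an open chain ending in a carboxylic acid is favoured here over an aromatic ring. The wider comparisons, which also change the other group on the amide-type nitrogen, give a 29-fold lower number from compound 2 to compound 4 (1.46 log units; beyond the scatter) and a 2.7-fold lower number from compound 1 to compound 4 (0.43 log units; beyond the scatter), so compound 4 now has the lowest number of the four, with each of its steps beyond the scatter. It also passes compound 1, so an ethyl group on that nitrogen, as in compound 3 and compound 4, is compatible with the tightest binding seen in this set.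

The compounds shown leave open whether the gain follows the carboxylic acid itself or simply the loss of the phenyl ring, a question that a plain pentyl chain, a methyl ester, a terminal amine or a longer or shorter acid chain at this position would help to settle. No supporting measurement accounts for the size of this gain.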